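Compound 1 and an ester-for-anilide swap

The source may hold more compounds than are shown below. What is called first, only, known or untested is meant among the compounds shown, and "the series" means these compounds.

Measured so far in a toxicity assay on L02 cells (Homo sapiens) for cytotoxicity, read by MTT assay, with a stated time of 24 h; a lower number here means that less compound is tolerated, a higher number that more compound is tolerated
compound 1 (`CCCCS(=O)(=O)Oc1ccc(/C=C/C(=O)Nc2ccccc2)cc1OC`) gives 3320 nM
compound 2 (`CCCCOC(=O)/C=C/c1ccc(OS(=O)(=O)c2ccc(Cl)cc2)c(OC)c1`) gives 14000 nM

Compound 1 stands lowest of these two numbers, and its gap to compound 2 lies beyond the usual scatter. Compound 3 (`CCCCS(=O)(=O)Oc1ccc(/C=C/C(=O)OCC)cc1OC`) keeps the core of compound 1 but carries ethoxy in place of anilino on a carbonyl carbon. Among the measured compounds shown here, no step between measured compounds is available to size this change. Compound 2 also lacks the anilino group and gives 14000 nM in this assay and on that ground alone a rise beyond the scatter is expected. The expected change is a moderate one (a 3.0-fold higher number from compound 1 to compound 3 (0.48 log units; beyond the scatter)). The estimate for compound 3 is 10000 nM (range 3500 nM to 30000 nM).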

Compound 3, half-maximal cytotoxic concentration: 14400 nM
Compound 3: middle estimate off by 1.4-fold (0.16 log units), on the low side; low and high end bracket the measured number.
By their numbers in this assay, from the lowest: compound 1; then compounds 2 and 3 (each within the scatter of the next).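

In this assay the swap of anilino for ethoxy on the carbonyl carbon gives a 4.3-fold higher number from compound 1 to compound 3 (0.64 log units; beyond the scatter) as a step on an otherwise unchanged core. Among the compounds shown here, compound 1 and compound 2 differ in more than one place, so only this pair ties a change beyond the scatter to this position alone. Nothing measured here accounts for the rise. From the compounds shown here alone, it remains open whether the step reflects the loss of anilino or the entry of ethoxy, which a longer chain such as butoxy or a carboxylic acid at this carbonyl carbon would help separate. Going by these compounds, whether the step carries over to another core also remains open.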